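Compound 3: aryl exchange relative to compound 1

This account rests on a few compounds, and the source may have more. Where it says the series, first, only, none or still open, it means among the compounds named here.

Among the measured compounds shown here, compound 1 `CCO/C(O)=C1\C(C)=NC(C)=C(C(=O)OCCCN2C(=O)c3ccccc3S2(=O)=O)C1c1cccc(Cl)c1Cl` gives 353 nM in a functional assay for inhibition, with Oryctolagus cuniculus as the target (a lower number here means a stronger inhibitor, a higher number a weaker inhibitor), the higher of the two numbers measured so far; compound 2 `CC1=NC(C)=C(C(=O)OCCCN2C(=O)c3ccccc3S2(=O)=O)C(c2cccc(Cl)c2Cl)/C1=C(\O)OC(C)C` gives 157 nM, and a 2.2-fold lower number from compound 1 to compound 2 (0.35 log units; beyond the scatter). Compound 3 `CCO/C(O)=C1\C(C)=NC(C)=C(C(=O)OCCCN2C(=O)c3ccccc3S2(=O)=O)C1c1ccccc1C(F)(F)F` differs from compound 1 by 2-(trifluoromethyl)phenyl in place of 2,3-dichlorophenyl on a saturated ring carbon. For the measured compounds named here, the only measured step, from compound 1 to compound 2, changes a saturated chain carbon bound to an oxygen and leaves the aryl group untouched, so no measured step bears on this change. Nothing in the series argues for a shift, so no step beyond the scatter is expected in this assay, with wide uncertainty. Compound 3 is therefore estimated at 350 nM, within 100 nM to 1200 nM, a step of a 1.0-fold lower number from compound 1 to compound 3 (0.00 log units; within the scatter).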

Compound 3, half-maximal inhibitory concentration: 124 nM
Compound 3: middle estimate off by 2.8-fold (0.45 log units), on the high side; low and high end bracket the measured number.
By their numbers in this assay, from the lowest: compounds 3 and 2 (each within the scatter of the next); then compound 1.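

In this assay the aryl group on the saturated ring carbon proves open to exchange, with a 2.8-fold lower number from compound 1 to compound 3 (0.45 log units; beyond the scatter) as 2-(trifluoromethyl)phenyl replaces 2,3-dichlorophenyl. Among the compounds shown here, the earlier step left this aryl group untouched, so this is the first sign that the number responds to a change at this position. No available evidence explains the step.

Which part of the exchange carries the step remains open, and a plain phenyl or a 2-chlorophenyl at this position would help separate the two. Also open, on these data alone, is whether this exchange and the added methyl of compound 2 would combine in a single compound.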